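The source may report more compounds than this note shows. Statements on the series, on what has been measured and on what is new or still open speak of the compounds shown alone.

Measured in a functional assay on HCT-116 cells (Homo sapiens) for antiproliferative activity, read by MTT assay, with a stated time of 48 h; on this read-out higher numbers stand for weaker inhibition and lower numbers for stronger inhibition:
compound 1 `CCCCCCCCCC(CCO)n1cnc2c(Cl)ncnc21` gives 890 nM
compound 2 `CCCCCCCCCC(CCO)n1cnc2c(OC)ncnc21` gives 2530 nM
compound 3 `CCCCCCCCCCC(CCO)n1cnc2c(Cl)ncnc21` gives 4930 nM

Compound 4 `CCCCCCCCCCC(CCO)n1cnc2c(OC)ncnc21` is not yet measured. Its core differs from the core of compound 1 by methyl in place of hydrogen on a saturated chain carbon, ten or more bonds along the chain from an aromatic nitrogen, a change that made a 5.5-fold higher number from compound 1 to compound 3 (0.74 log units; beyond the scatter). The change from compound 3 to compound 4 is methoxy in place of chloro on an aromatic carbon. The same change, made on compound 1, gives compound 2 methoxy in place of chloro on an aromatic carbon and made a 2.8-fold higher number from compound 1 to compound 2 (0.45 log units; beyond the scatter); the place of the change reads the same in both cases, so it is the same change. Because that change made a 2.8-fold higher number from compound 1 to compound 2 (0.45 log units; beyond the scatter), the step from compound 3 to compound 4 is expected to be a 2.8-fold higher number from compound 3 to compound 4 (0.45 log units; beyond the scatter). Compound 4 is therefore expected to give 13800 nM in this assay. The range expected for compound 4 runs from 5000 nM to 38000 nM.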

Compound 4, half-maximal inhibitory concentration: 7530 nM
Compound 4: the middle estimate sits 1.8-fold (0.26 log units) above what was measured; the range from low to high includes it.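

In this assay, methoxy in place of chloro on an aromatic carbon gives a 1.5-fold higher number from compound 3 to compound 4 (0.18 log units; within the scatter) on the longer-chain core, and the two steps for this change do not differ beyond the scatter: the same change on two cores in this assay, a 2.8-fold higher number (0.45 log units; beyond the scatter) from compound 1 to compound 2 and a 1.5-fold higher number (0.18 log units; within the scatter) from compound 3 to compound 4, 1.9-fold (0.27 log units) apart, within the scatter of two such steps. Methyl in place of hydrogen on a saturated chain carbon gives a 3.0-fold higher number from compound 2 to compound 4 (0.47 log units; beyond the scatter) on the methoxy core, and this change also carries across: the same change on two cores in this assay, a 5.5-fold higher number (0.74 log units; beyond the scatter) from compound 1 to compound 3 and a 3.0-fold higher number (0.47 log units; beyond the scatter) from compound 2 to compound 4, 1.9-fold (0.27 log units) apart, within the scatter of two such steps. The two changes therefore combine consistently across these four compounds, but this does not show that either step has exactly the same size on both cores, or that it would carry to any other core.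

Going by these compounds, whether the pattern holds with an amine on that aromatic carbon, or with a longer chain, remains open.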